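Fluoro to Chloro: a Small Halogen Swap Tested

The compounds below may be only part of what the source reports. "The series", "measured", "known", "first", "only" and "open" are said of these compounds alone.

Compound 1, `Nc1scc(CN2CCN(c3cc(Cl)cc(Cl)c3)CC2)c1C(=O)c1ccc(Cl)cc1` — in an assay on CHO cells for displacement of a labelled ligand from adenosine receptor A3 (Homo sapiens), read by scintillation counting, with a stated time of 120 min, tested at 10 uM (on this read-out higher numbers stand for more inhibition at the one concentration tested (going by the name of the read-out) and lower numbers for less inhibition), compound 1 gives 1%.
Compound 2, `Nc1scc(CN2CCN(c3ccc(F)c(Cl)c3)CC2)c1C(=O)c1ccc(Cl)cc1` — in this assay compound 2 gives 0%.

Both measured compounds share one core and differ only in the substituted phenyl ring on an amine nitrogen in a ring. Compound 2 carries the 3-chloro-4-fluorophenyl group, and its number sits together with that of compound 1, as the change a number 1 percentage points lower from compound 1 to compound 2 (within the scatter) shows; neither compound displaces the labelled ligand to any meaningful degree at the single concentration tested.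

Compound 3, `Nc1scc(CN2CCN(c3ccc(Cl)c(Cl)c3)CC2)c1C(=O)c1ccc(Cl)cc1`, is the next member of this small series and has not yet been measured. It differs from compound 2 by chloro in place of fluoro on an aromatic carbon. Within the data shown here, the one measured step, from 3,5-dichlorophenyl to 3-chloro-4-fluorophenyl, altered the halogen pattern on this same ring and produced no movement beyond the scatter. Another halogen rearrangement on this ring is therefore expected to behave alike, and no step beyond the scatter is expected: a number 1 percentage points higher from compound 2 to compound 3 (within the scatter). Compound 3 is estimated to give 1%, within a range from -8% to 10%.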

Compound 3, a percentage reported as inhibition, at one concentration (the size of the read-out at that concentration, not a potency): 3%
For compound 3 the middle estimate is 2 percentage points below the measured one; the measured number falls inside the stated range.
By their numbers in this assay, from the lowest: compounds 2, 1 and 3 (each within the scatter of the next).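

Replacing fluoro with chloro on the aromatic carbon para to a large group gives a number 3 percentage points higher from compound 2 to compound 3 (within the scatter) in this assay, so this position, tested with these two halogens, shows no readable response to the exchange. The earlier pair differed in the halogen pattern as a whole, whereas this step isolates a single atom on a single carbon. The comparison of the two dichlorophenyl patterns gives a number 2 percentage points higher from compound 1 to compound 3 (within the scatter), so the 3,4-dichlorophenyl and 3,5-dichlorophenyl groups cannot be told apart in this test, and nothing measured here explains why the numbers stay together.

All three compounds carry only halogens on this ring and all sit close to the bottom of the scale, so a flat result here cannot show how much this position would matter in a compound that displaces the labelled ligand clearly. Going by these compounds, whether a methoxy group or an amine in this place would bring a number out of the scatter stays open, as does the effect of any change elsewhere on the shared core.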